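The source may hold more compounds than are shown below. What is called first, only, known or untested is meant among the compounds shown, and "the series" means these compounds.

For the measured compounds named here, compound 1 `CN1CCC(C(=O)N2Cc3c(NC(=O)C4CCC4)n[nH]c3C2(C)C)CC1` gives 140 nM in a functional assay on A2780 cells (Homo sapiens) for antiproliferative activity, read by fluorescence, with a stated time of 72 h (a lower number here means a stronger inhibitor, a higher number a weaker inhibitor), the lower of the two numbers measured so far; compound 2 `CC(C)CC(=O)Nc1n[nH]c2c1CN(C(=O)C1CCN(C3CC3)CC1)C2(C)C` gives 320 nM in this assay, a gap beyond the scatter. Compound 3 `CN1CCC(C(=O)N2Cc3c(NC(=O)c4ccncc4)n[nH]c3C2(C)C)CC1` differs from compound 1 in one place: pyridin-4-yl in place of cyclobutyl on a carbonyl carbon. Going by the values given here, no measured pair shows this change, so its direction is unknown. A step of no more than modest size, possibly within the scatter, is expected from compound 1 to compound 3 in this assay, as a 1.1-fold higher number from compound 1 to compound 3 (0.03 log units; within the scatter). Compound 3 is therefore estimated at 150 nM, with a range of 50 nM to 500 nM.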

Compound 3, half-maximal inhibitory concentration: 500 nM
Beside the measured number, compound 3's estimate is 3.3-fold (0.52 log units) below it, within the range that was stated.
By their numbers in this assay, from the lowest: compound 1; then compounds 2 and 3 (each within the scatter of the next).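

In this assay, for the compounds shown here, this carbonyl position is not indifferent to its substituent: pyridin-4-yl in place of cyclobutyl gives a 3.6-fold higher number from compound 1 to compound 3 (0.55 log units; beyond the scatter) in the first one-place comparison of the series. The change replaces a non-aromatic carbon ring with a larger aromatic ring that carries one hydrogen-bond acceptor, and this single pair cannot separate those differences. Nothing measured here accounts for the step. Open, going by these compounds, is whether phenyl on the same carbonyl carbon would track cyclobutyl or pyridin-4-yl, which would separate the aromatic ring from its nitrogen.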